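Changing the piperidine substituent in an antiproliferative series

This account rests on a few compounds, and the source may have more. Where it says the series, first, only, none or still open, it means among the compounds named here.

In a functional assay on SH-SY5Y cells (Homo sapiens) for antiproliferative activity, read by MTT assay, with a stated time of 72 h (a lower number here means a stronger inhibitor, a higher number a weaker inhibitor), compound 1 (`COc1cc2c(Nc3ccc(C#N)cc3)ncnc2cc1OCCCN(C)C`) gives 34900 nM and compound 3 (`CCOC(=O)C1CCN(CCCOc2cc3ncnc(Nc4ccc(C#N)cc4)c3cc2OC)CC1`) gives 47200 nM, two values within the scatter of each other. In this assay, compound 2 (`COc1cc2c(Nc3ccc(C#N)cc3)ncnc2cc1OCCCN1CCC(O)CC1`) gives only a limit, > 100000 nM.

Compound 4 (`COc1cc2c(Nc3ccc(C#N)cc3)ncnc2cc1OCCCN1CCC(N(C)C)CC1`) is not yet measured. Its difference from compound 3 is dimethylamino in place of ethoxycarbonyl on a saturated ring carbon.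

Within the data shown here, two measured steps bear on this change. On the same ring carbon, hydroxy and ethoxycarbonyl are compared in an at least 2.1-fold lower number from compound 2 to compound 3 (0.32 log units; beyond the scatter), which is beyond the scatter but bounded by a limit. Replacing the dimethylamino end of the chain with 4-(ethoxycarbonyl)piperidin-1-yl gives a 1.4-fold higher number from compound 1 to compound 3 (0.13 log units; within the scatter), within the scatter. Among the measured compounds shown here, no measured compound carries the new substituent, so the expectation rests mainly on this second step, and no change beyond the scatter is expected in this assay. The expected step is a 1.3-fold lower number from compound 3 to compound 4 (0.12 log units; within the scatter). For compound 4 the estimated value is 36000 nM, with an expected range of 12000 nM to 100000 nM.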

Compound 4, half-maximal inhibitory concentration: 24300 nM
Beside the measured number, compound 4's estimate is 1.5-fold (0.17 log units) above it; the measured number falls inside the stated range.
By their numbers in this assay, from the lowest: compounds 4, 1 and 3 (each within the scatter of the next). At a limit, above all of these: compound 2.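

In this assay, dimethylamino on the saturated ring carbon, three ring bonds from the ring nitrogen, behaves like the groups already seen: a 1.9-fold lower number from compound 3 to compound 4 (0.29 log units; within the scatter) and a 1.4-fold lower number from compound 1 to compound 4 (0.16 log units; within the scatter) both leave the number within the scatter, so neither replacing ethoxycarbonyl nor extending the chain end to 4-(dimethylamino)piperidin-1-yl separates these compounds. Hydroxy at this ring carbon is the one group that stands apart, as dimethylamino now also shows: an at least 4.1-fold lower number from compound 2 to compound 4 (0.61 log units; beyond the scatter), a step beyond the scatter. For compound 2 there is only a limit and not a number, so the full size of that step cannot be read: the limit of > 100000 nM in this assay, at which 1 of the 4 values shown sits.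

From the compounds shown here alone, whether a carboxylic acid or a primary amine on the same ring carbon would move the number beyond the scatter stays open. Going by these compounds, the effect of a longer chain in place of the present one on these piperidine groups is also open.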